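The compounds below may be only part of what the source reports. "The series", "measured", "known", "first", "only" and "open" are said of these compounds alone.

Measured compounds:
compound 1 `C=C1C[C@]23C[C@@]1(O)CC[C@@H]2c1cccc(C)c1[C@@H]3Cn1cc(-c2ccc(OC)cc2)nn1`, > 20000 nM
compound 2 `Cc1ccc(-c2cn(C[C@H]3c4c(ccc(O)c4C)[C@@H]4CC[C@@]5(C)C[C@]43CC5=O)nn2)cc1`, > 20000 nM
compound 3 `C=C1C[C@]23C[C@@]1(O)CC[C@@H]2c1cccc(C)c1[C@@H]3Cn1cc(-c2ccc(C)cc2)nn1`, > 20000 nM

In a functional assay on HL-60 cells (Homo sapiens) for cytotoxicity, read by MTT assay, with a stated time of 4 days (a lower number here means a stronger inhibitor, a higher number a weaker inhibitor), compound 3 gives > 20000 nM, which is a limit of the assay and not a number. Compound 1 gives > 20000 nM in this assay, again a limit. Compound 2 gives > 20000 nM in this assay, also a limit. Compound 1 differs from compound 3 by methoxy in place of methyl on an aromatic carbon; the step that the two limits leave unreadable from compound 3 to compound 1 cannot be read because of the limit of > 20000 nM in this assay, at which 3 of the 3 values shown sit. Compound 4 `COc1ccc(-c2cn(C[C@H]3c4c(ccc(O)c4C)[C@@H]4CC[C@@]5(C)C[C@]43CC5=O)nn2)cc1` differs from compound 2 by methoxy in place of methyl on an aromatic carbon, the same change at the same place. How the cores of compound 2 and compound 3 differ is not broken down here. Compound 4 is expected to give 30000 nM in this assay, between 15000 nM and 100000 nM. The expected step is a step that the limit leaves unreadable from compound 2 to compound 4, resting on the limit that compound 2 shows at > 20000 nM.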

Compound 4, half-maximal inhibitory concentration: > 20000 nM
Compound 4 gave a limit, no number; the forecaster's own chance of this, stated with the estimate: 85%; the middle value is on the limit's open side.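

No step can be read from compound 2 to compound 4, and the step from compound 3 to compound 1 stays equally unreadable, because all four values are limits and not numbers: the limit of > 20000 nM in this assay, at which 4 of the 4 values shown sit. The compounds shown leave open whether changing 4-methylphenyl to 4-methoxyphenyl has any effect on either core.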